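Swapping Chloro for Methyl on the Anilino Ring

The source may hold more compounds than are shown below. What is called first, only, known or untested is meant among the compounds shown, and "the series" means these compounds.

Going by the values given here, compound 3 `CCOc1ccc(Cl)cc1-c1cc(N)nc(Nc2ccc(Cl)cc2)c1` gives 50 nM in an assay on Sf9 cells for inhibition of 1-acyl-sn-glycerol-3-phosphate acyltransferase beta (Homo sapiens) (on this read-out higher numbers stand for weaker inhibition and lower numbers for stronger inhibition), the lowest of the three numbers measured so far. Compound 1 `COc1ccc(Cl)cc1-c1cc(N)nc(Nc2ccc(C)cc2)c1` gives 240 nM in this assay and compound 2 `COc1ccc(Cl)cc1-c1cc(N)nc(Nc2ccc(C=O)cc2)c1` gives 260 nM; both stand well apart from compound 3, as each differs from it in two places. Among the compounds with values here, the only measured single change, a 1.1-fold higher number from compound 1 to compound 2 (0.03 log units; within the scatter), lies within the scatter. Compound 4 `CCOc1ccc(Cl)cc1-c1cc(N)nc(Nc2ccc(C)cc2)c1` differs from compound 3 by methyl in place of chloro on an aromatic carbon. Within the data shown here, no measured pair isolates this exchange: compound 1 and compound 3 differ in two places, and the step from compound 1 to compound 2 concerns formyl against methyl rather than chloro against methyl. Among the measured compounds shown here, that step hints that this position accepts exchange without a large shift, yet chloro itself has no measured counterpart. Compound 4 is therefore expected to give 100 nM in this assay, with a range of 40 nM to 250 nM, an expected step of a 2.0-fold higher number from compound 3 to compound 4 (0.30 log units; within the scatter).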

Compound 4, half-maximal inhibitory concentration: 490 nM
Beside the measured number, compound 4's estimate is 4.9-fold (0.69 log units) below it; measured number outside the range, above it.
By their numbers in this assay, from the lowest: compound 3; then compounds 1, 2 and 4 (each within the scatter of the next, the first and the last beyond it).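

Going by these compounds alone, with this assay, the exchange on this ring carbon is isolated for the first time: going from 4-chlorophenyl to 4-methylphenyl gives a 9.8-fold higher number from compound 3 to compound 4 (0.99 log units; beyond the scatter), so this position is not indifferent to every exchange, although a 1.1-fold higher number from compound 1 to compound 2 (0.03 log units; within the scatter) had suggested that it might be. The second new step, a 2.0-fold higher number from compound 1 to compound 4 (0.31 log units; beyond the scatter), shows that methyl in place of hydrogen on the saturated chain carbon bound to the oxygen also matters, though this step is much smaller than the exchange of chloro for methyl. Nothing at hand accounts for either step. From the compounds shown here alone, it remains open whether chloro keeps its lead when the chain on the oxygen is shorter. Fluoro, bromo or trifluoromethyl at this ring carbon could fall nearer to either chloro or methyl.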